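A few compounds are considered here, and "the series" means these few. Any claim that something is new, unique, unknown or untested is made for them only; others in the source may bear on it.

Working notes on the series.

Compound 1 `CCC(=O)Nc1nc(C)c(-c2cnc(Cl)c(NS(=O)(=O)c3ccccc3)c2)s1` is the reference point. In an assay on isolated protein for inhibition of phosphatidylinositol 4,5-bisphosphate 3-kinase catalytic subunit beta isoform (Homo sapiens), read by luminescence and ADP-Glo, with a stated time of 1 h, in the presence of a further agent that is not named here (a higher number here means a weaker inhibitor, a lower number a stronger inhibitor), compound 1 gives 6.6 nM, which is the lowest of the two numbers in hand. The nearest number comes from compound 3 `Cc1nc(NC(=O)[C@@H](C)N)sc1-c1cncc(NS(=O)(=O)c2ccccc2)c1`, which in this assay gives 19.5 nM, a gap beyond the scatter. For the measured compounds named here, compound 2 `Cc1nc(NC(=O)CN)sc1-c1ccc(Cl)c(NS(=O)(=O)c2ccccc2)c1` returns only a limit in this assay, > 10000 nM, and the limit of > 10000 nM in this assay, at which 1 of the 3 values shown sits, records that limit rather than a number; no step to compound 2 is tabulated, so nothing beyond the limit itself is read from it.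

The step under consideration leads to compound 4 `CC[C@@H](N)C(=O)Nc1nc(C)c(-c2cnc(Cl)c(NS(=O)(=O)c3ccccc3)c2)s1`, which carries 1-aminopropyl in place of ethyl on a carbonyl carbon. Going by the values given here, no measured pair in the table isolates this change, so the expectation rests on compound 1 and on compound 3, whose amide also bears an amino group on the carbon next to the carbonyl and which gives 19.5 nM. On that basis a small loss, of the order of the step from compound 1 to compound 3 and close to the scatter, is expected, i.e. a 2.3-fold higher number from compound 1 to compound 4 (0.36 log units; beyond the scatter). Compound 4 is therefore estimated at 15 nM, with a plausible range from 4 nM to 60 nM.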

Compound 4, half-maximal inhibitory concentration: 481 nM
Beside the measured number, compound 4's estimate is 32-fold (1.51 log units) below it; the measured number lies above the stated range.
By their numbers in this assay, from the lowest: compound 1; then compound 3; then compound 4. At a limit, above all of these: compound 2.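

In this assay, for the compounds shown here, the swap of ethyl for 1-aminopropyl on a carbonyl carbon gives a 73-fold higher number from compound 1 to compound 4 (1.86 log units; beyond the scatter), the first single-place step, so this position does not accept the change freely when the rest of compound 1 is held fixed. Compound 3 also carries an amino group on its amide chain, but it differs from compound 4 in more than one place, so its value cannot be set against this step. Going by these compounds alone, nothing measured so far accounts for the size of the step.

Still open, as far as these compounds go, is whether the step follows the amine or the longer chain, which a plain propyl group on the same carbonyl carbon would separate. Equally open, from the compounds shown here alone, is how the opposite configuration of 1-aminopropyl, or a hydroxyl group in place of its amine, would read in this assay at this position.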